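Swapping Anilino for Phenoxy on a Carbonyl Carbon

This account rests on a few compounds, and the source may have more. Where it says the series, first, only, none or still open, it means among the compounds named here.

In a functional assay on HCT-15 cells (Homo sapiens) for antiproliferative activity (a lower number here means a stronger inhibitor, a higher number a weaker inhibitor), compound 1 `COc1ccc(S(=O)(=O)Oc2ccccc2NC(=O)Nc2ccccc2)cc1` reaches only a limit, > 10000 nM, and not a number. Two relatives with the same core give real numbers: compound 2 `COc1ccc(S(=O)(=O)Oc2ccccc2NC(=O)c2ccc(F)cc2)cc1` gives 89 nM, and compound 3 `COc1ccc(S(=O)(=O)Oc2ccccc2NC(=O)c2ccco2)cc1` gives 19 nM. The next compound, compound 4 `COc1ccc(S(=O)(=O)Oc2ccccc2NC(=O)Oc2ccccc2)cc1`, keeps that core and changes one group: phenoxy in place of anilino on a carbonyl carbon. In words, phenoxy takes the place of anilino on a carbonyl carbon.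

Within the data shown here, no measured step makes this exact change, but two also remove the anilino. They are large: an at least 110-fold lower number from compound 1 to compound 2 (2.05 log units; beyond the scatter) and an at least 520-fold lower number from compound 1 to compound 3 (2.72 log units; beyond the scatter). The choice of replacement also matters, though more modestly: a 4.7-fold lower number from compound 2 to compound 3 (0.67 log units; beyond the scatter). Since phenoxy differs from both 4-fluorophenyl and furan-2-yl, a large fall in this assay is expected, probably less complete than in those two steps. The expected step is an at least 25-fold lower number from compound 1 to compound 4 (1.39 log units; beyond the scatter). For compound 4 the estimated value is 400 nM, with an expected range from 40 nM to 6000 nM.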

Compound 4, half-maximal inhibitory concentration: > 10000 nM
Compound 4 was reported as a limit; the forecaster's own chance of this, stated with the estimate: 15%; middle value at least 25-fold (1.39 log units) from the limit.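

In this assay, compound 4 with phenoxy on the carbonyl carbon ends at a limit and not at a number, the same limit as compound 1: the limit of > 10000 nM in this assay, at which 2 of the 4 values shown sit. Moving to phenoxy gives an at least 520-fold higher number from compound 3 to compound 4 (2.72 log units; beyond the scatter) against furan-2-yl and an at least 110-fold higher number from compound 2 to compound 4 (2.05 log units; beyond the scatter) against 4-fluorophenyl, so trading the nitrogen of anilino for the oxygen of phenoxy, and with it the hydrogen-bond donor, does not restore a measurable value. The step between compound 1 and compound 4 cannot be read, but among these four compounds the two groups joined to the carbonyl carbon through nitrogen or oxygen sit at the limit, and the two joined through carbon give numbers.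

As far as these compounds go, how far compound 1 and compound 4 lie beyond the limit stays unknown. Also open, from the compounds shown here alone, is whether methoxy or dimethylamino would stay at the limit, and whether benzyl would give a number.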